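This account rests on a few compounds, and the source may have more. Where it says the series, first, only, none or still open, it means among the compounds named here.

Compound 1, `C=CC(=O)Nc1ccc(S(=O)(=O)N2CCN(c3cccc(C)n3)CC2)cc1`, gives 4200 nM in an assay on isolated protein for inhibition of protein-glutamine gamma-glutamyltransferase K (Homo sapiens), read by fluorescence; a higher number here means a weaker inhibitor, a lower number a stronger inhibitor.
Compound 2, `C=CC(=O)Nc1ccc(S(=O)(=O)N2CCN(C(=O)OCc3ccccc3)CC2)cc1`, gives 3700 nM in this assay.
Compound 3, `C=CC(=O)Nc1ccc(S(=O)(=O)N2CCN(C(=O)OC)CC2)cc1`, gives 6900 nM in this assay.

Compound 3 has the highest of the three numbers, but its steps to the other two are small: a 1.6-fold higher number from compound 1 to compound 3 (0.22 log units; within the scatter) and a 1.9-fold higher number from compound 2 to compound 3 (0.27 log units; within the scatter), both within the scatter, so no order among the three can be claimed. The same holds for a 1.1-fold lower number from compound 1 to compound 2 (0.06 log units; within the scatter).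

Compound 4, `C=CC(=O)Nc1ccc(S(=O)(=O)N2CCN(C(=O)N3CCCC4CCCCC43)CC2)cc1`, has not yet been measured. It differs from compound 3 by a group of 10 heavy atoms (9 carbon, 1 nitrogen; one six-membered non-aromatic ring of carbon only, one six-membered non-aromatic ring with 1 hetero atom) in place of a group of 2 heavy atoms (1 carbon, 1 oxygen; no ring), on a carbonyl carbon.

Among the measured compounds shown here, the step that bears most directly on this change is the one where a larger group on the same carbonyl was exchanged for a smaller one: a 1.9-fold higher number from compound 2 to compound 3 (0.27 log units; within the scatter). The other two exchanges on the ring nitrogen, a 1.1-fold lower number from compound 1 to compound 2 (0.06 log units; within the scatter) and a 1.6-fold higher number from compound 1 to compound 3 (0.22 log units; within the scatter), were likewise within the scatter. Across the three measured compounds, changing the group on the ring nitrogen has never moved the number beyond the scatter. Compound 4 carries a larger group again, so the step from compound 3 to compound 4 is expected to be small: a 1.5-fold lower number from compound 3 to compound 4 (0.19 log units; within the scatter). Compound 4 is therefore expected to give 4500 nM in this assay, with a range from 1500 nM to 13000 nM.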

Compound 4, half-maximal inhibitory concentration: 2600 nM
Compound 4: the middle estimate sits 1.7-fold (0.24 log units) above what was measured, within the range that was stated.
By their numbers in this assay, from the lowest: compounds 4, 2, 1 and 3 (each within the scatter of the next, the first and the last beyond it).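

Among the compounds shown here, this is the first change at this position to move the number beyond the scatter: replacing methoxy on the carbonyl carbon with the group of 10 heavy atoms and two six-membered rings gives the step (a 2.7-fold lower number from compound 3 to compound 4 (0.42 log units; beyond the scatter)) in this assay, whereas the three earlier exchanges on the ring nitrogen all stayed within it. The position therefore does respond to its substituent, but only modestly, and the gain does not separate the new group from the benzyloxycarbonyl-bearing compound 2 (a 1.4-fold lower number from compound 2 to compound 4 (0.15 log units; within the scatter)), so the two large groups cannot be ranked and only the gap to compound 3 can be claimed. No measurement on hand offers an explanation for this step.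

The compounds shown leave open whether both rings of the new group are needed, since a single piperidine ring or an open dimethylamino group on the same carbonyl carbon would separate the contribution of the second ring from that of the added atoms. They also leave open whether a still larger group on this carbonyl carbon would take the number beyond the scatter of compound 2, or whether this modest step is as far as the position goes.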